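Dropping the Bromo Group from Compound 1

This account rests on a few compounds, and the source may have more. Where it says the series, first, only, none or still open, it means among the compounds named here.

Three isoxazolidine-bearing chromones were tested in a functional assay on A549 cells (Homo sapiens) for inhibition, read by sulforhodamine B assay, with a stated time of 48 h; a lower number here means a stronger inhibitor, a higher number a weaker inhibitor. Compound 1, `CCO[C@H]1C[C@@H](c2coc3ccc(Br)cc3c2=O)N(c2ccccc2)O1`, gives 21500 nM in this assay. Compound 2, `N#C[C@H]1C[C@@H](c2coc3ccc(Cl)cc3c2=O)N(c2ccccc2)O1`, gives 40000 nM. Compound 3, `COC(=O)[C@@]1(C)C[C@@H](c2coc3ccc(C)cc3c2=O)N(c2ccccc2)O1`, gives 700 nM. Among these three numbers compound 1 stands second highest. Its nearest neighbour is compound 2, whose value lies within the usual scatter of the measurement, so the two cannot be told apart in this assay. Compound 3 is the furthest away, with a markedly lower number that lies well beyond the scatter; compound 3 differs from compound 1 in several places at once, so no single cause can be read from the pair.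

The next compound, compound 4, `CCO[C@H]1C[C@@H](c2coc3ccccc3c2=O)N(c2ccccc2)O1`, differs from compound 1 in one place only: hydrogen in place of bromo on an aromatic carbon. Within the data shown here, no directly comparable pair of measured compounds shows what this change does. Among the measured compounds shown here, with compound 1 at 21500 nM and no matching precedent, the step expected a 1.4-fold higher number from compound 1 to compound 4 (0.14 log units; within the scatter) is small and upward, modest but possibly inside the scatter. Compound 4 is therefore estimated at 30000 nM, with a plausible range from 10000 nM to 90000 nM.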

Compound 4, half-maximal inhibitory concentration: > 60000 nM
Compound 4: only a limit was reported; the forecaster's own chance of this, stated with the estimate: 25%; middle value at least 2.0-fold (0.30 log units) from the limit.
By their numbers in this assay, from the lowest: compound 3; then compounds 1 and 2 (each within the scatter of the next). At a limit, above all of these: compound 4.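

Among these compounds, replacing the bromo group with hydrogen gives the first single-place comparison in this set, and it shows that this aromatic carbon is not indifferent to substitution in this assay: the change gives an at least 2.7-fold higher number from compound 1 to compound 4 (0.44 log units; beyond the scatter), so the compound with hydrogen here is the weaker inhibitor. The reading for compound 4 is a limit of the assay and not a number: the limit of > 60000 nM in this assay, at which 1 of the 4 values shown sits. The step therefore has a lower bound only, and the finding applies to the core of compound 1 alone.

The compounds shown leave open whether the same change would act alike on the cores of compound 2 and compound 3. They also leave open how an amine or a carboxylic acid on this aromatic carbon would compare with bromo.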